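Replacing the 4-(methylsulfonyl)phenyl group of compound 1

A few compounds are considered here, and "the series" means these few. Any claim that something is new, unique, unknown or untested is made for them only; others in the source may bear on it.

In a functional assay (Homo sapiens) for inhibition (on this read-out higher numbers stand for weaker inhibition and lower numbers for stronger inhibition), compound 1 `CS(=O)(=O)c1ccc(CSc2nc(-c3ccc(F)cc3)c(-c3ccncc3)[nH]2)cc1` gives 330 nM as its reading. Compound 2 `CS(=O)(=O)c1ccc(CSc2nc(-c3ccc(Cl)cc3)c(-c3ccncc3)[nH]2)cc1` gives 320 nM with chloro in place of fluoro on an aromatic carbon, and compound 3 `CS(=O)(=O)c1ccc(CSc2nc(-c3ccc(Br)cc3)c(-c3ccncc3)[nH]2)cc1` gives 640 nM with bromo in place of fluoro. The halogen exchanges give a 1.0-fold lower number from compound 1 to compound 2 (0.01 log units; within the scatter) and a 1.9-fold higher number from compound 1 to compound 3 (0.29 log units; within the scatter) and also a 2.0-fold higher number from compound 2 to compound 3 (0.30 log units; within the scatter) as steps, all within the scatter, so compound 1 holds no distinct place among the three.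

Compound 4 `CSc1cc(CSc2nc(-c3ccc(F)cc3)c(-c3ccncc3)[nH]2)ccc1O` keeps the fluoro group but carries 4-hydroxy-3-(methylsulfanyl)phenyl in place of 4-(methylsulfonyl)phenyl on a saturated chain carbon bound to a sulfur, with 4-hydroxy-3-(methylsulfanyl)phenyl in place of 4-(methylsulfonyl)phenyl on a saturated chain carbon bound to a sulfur as the counted change. Within the data shown here, no measured step touches this group, so the halogen steps bear on it only indirectly. Starting from compound 1 at 330 nM with no direct guide, no step beyond the scatter is expected in this assay for this exchange, though with wide uncertainty. The expected step is a 1.1-fold lower number from compound 1 to compound 4 (0.04 log units; within the scatter) as a central guess. For compound 4 the estimated value is 300 nM within an expected range of 70 nM to 1300 nM for repeated measurements.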

Compound 4, half-maximal inhibitory concentration: 280 nM
Compound 4: the middle estimate sits 1.1-fold (0.03 log units) above what was measured; the range from low to high includes it.
By their numbers in this assay, from the lowest: compounds 4, 2, 1 and 3 (each within the scatter of the next, the first and the last beyond it).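

Unlike the halogen exchanges, this change reaches the group on a saturated chain carbon bound to a sulfur, and in this assay it gives a 1.2-fold lower number from compound 1 to compound 4 (0.07 log units; within the scatter). The 4-(methylsulfonyl)phenyl group can therefore give way to 4-hydroxy-3-(methylsulfanyl)phenyl, which brings a hydrogen-bond donor and loses the double bonds outside the ring, without a step beyond the scatter on this read-out. Nothing at hand accounts for this reading.

The hydroxy and methylsulfanyl groups enter together, so the compounds shown cannot separate what each contributes to the reading. As far as these compounds go, it also remains open how an amine or a carboxylic acid would read on this ring, and whether the exchange gives the same result with chloro or bromo in place of fluoro.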